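The source may report more compounds than this note shows. Statements on the series, on what has been measured and on what is new or still open speak of the compounds shown alone.

Measured so far:
compound 1, `N[C@H]1CC[C@H](Nc2c(C(=O)NCc3ccccn3)nc(Br)c3cccnc23)CC1`: 4000 nM
compound 2, `COC(=O)CNc1c(C(=O)NCc2ccc(F)cc2)nc(Br)c2cccnc12`: 10000 nM
compound 3, `CN(C)c1ccc(CNC(=O)c2nc(Br)c3cccnc3c2N[C@H]2CC[C@H](N)CC2)cc1`: 4000 nM

All three numbers come from a functional assay on MDA-MB-435 cells (Homo sapiens) for cytotoxicity, read by MTT assay, with a stated time of 72 h; a lower number here means a stronger inhibitor, a higher number a weaker inhibitor. Compound 2 stands highest of the three; compound 1 and compound 3, which share an identical value, both lie below it by a margin beyond the scatter. Compound 1 and compound 3 carry the same amine on the core and differ only at the amide side, where no change at the digits printed from compound 1 to compound 3 (within the scatter), so that change reads as neutral.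

Compound 4, `CN(C)CCCNc1c(C(=O)NCc2ccc(F)cc2)nc(Br)c2cccnc12`, keeps the amide side of compound 2 and alters the substituent on the amine attached to the core: 2-(dimethylamino)ethyl in place of methoxycarbonyl on a saturated chain carbon bound to a nitrogen on an aromatic ring

Going by the values given here, no measured step covers this position. Among the compounds with values here, the single step on record, from compound 1 to compound 3, concerns the amide side and tells nothing about the amine on the core. What the numbers do show is that compound 1 and compound 3, each bearing a basic amine on that side, sit below compound 2, which carries none. On that basis compound 4 is expected to move toward those two, a step of a 3.3-fold lower number from compound 2 to compound 4 (0.52 log units; beyond the scatter) in the direction of a lower number, with wide uncertainty. The estimate for compound 4 is 3000 nM, within 1000 nM to 9000 nM.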

Compound 4, half-maximal inhibitory concentration: 7000 nM
Beside the measured number, compound 4's estimate is 2.3-fold (0.37 log units) below it, within the range that was stated.
By their numbers in this assay, from the lowest: compounds 1, 3, 4 and 2 (each within the scatter of the next, the first and the last beyond it).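

Going by these compounds alone, this is the first reading at the amine attached to the core, with the amide side of compound 2 held fixed: in this assay, the exchange of (methoxycarbonyl)methyl for 3-(dimethylamino)propyl gives a 1.4-fold lower number from compound 2 to compound 4 (0.15 log units; within the scatter) and so reads as neutral. The exchange is not small in atoms, since methoxycarbonyl with its two oxygens and its carbonyl leaves and 2-(dimethylamino)ethyl with its nitrogen enters, yet the number stays within the scatter, so a terminal dimethylamino on this chain does not by itself separate compound 4 from compound 2. No measurement on hand offers an explanation for this result.

Compound 1 and compound 3 differ from compound 4 in more than one place, so the role of their amine on the core cannot be read from this step, and pairing that amine with the amide side of compound 2 would be the direct test. Also open, going by these compounds, is whether a carboxylic acid in place of methoxycarbonyl, or a longer chain in place of 3-(dimethylamino)propyl, would move the number beyond the scatter.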